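The compounds below may be only part of what the source reports. "The series", "measured", "known", "first", "only" and "open" are said of these compounds alone.

Measured in an ADME assay on MT4 cells (Homo sapiens) for cytotoxicity, read by MTT assay, with a stated time of 4 days; a lower number here means that less compound is tolerated, a higher number that more compound is tolerated:
- Compound 1 `CCCN(CCC)c1nc(Cc2c(F)cccc2F)cc(=O)[nH]1`: > 78000 nM, a limit
- Compound 2 `CC1CCN(c2nc(Cc3c(F)cccc3F)cc(=O)[nH]2)CC1`: > 78000 nM, a limit

Compound 2 has no number in this assay, only the limit > 78000 nM. Compound 1 likewise has only a limit, > 78000 nM. Compound 3 `O=c1cc(Cc2c(F)cccc2F)nc(N2CCCCCC2)[nH]1` is still unmeasured. It carries azepan-1-yl in place of the 4-methylpiperidin-1-yl of compound 2, on an aromatic carbon between two ring nitrogen atoms: azepan-1-yl in place of 4-methylpiperidin-1-yl on an aromatic carbon.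

One measured step changes the group at this place: a step that the two limits leave unreadable from compound 1 to compound 2. Its size cannot be read, so it gives no measure of how far such a change can move the result. What the two compounds do share is the limit of > 78000 nM in this assay, at which 2 of the 2 values shown sit.

Resting on compound 2 at the limit > 78000 nM, no step beyond the scatter is expected in either direction. The expected step is a number no higher from compound 2 to compound 3 (the limit leaves the size open). A report of compound 3 as a limit again would be the likeliest outcome. The estimate for compound 3 is 78000 nM, with an expected range from 30000 nM to 150000 nM.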

Compound 3, half-maximal cytotoxic concentration: > 78000 nM
Compound 3: no number, only a limit; the forecaster's own chance of this, stated with the estimate: 75%; the middle value sits exactly at the limit.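

In this assay compound 3 gives > 78000 nM as a limit. Among the compounds shown here, no step among compound 1, compound 2 and compound 3 can be read, and they share one result: the limit of > 78000 nM in this assay, at which 3 of the 3 values shown sit. The compounds shown leave open where each one's half-maximal cytotoxic concentration actually lies, and whether changing the group at this place moves it at all.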